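From 3-nitrophenyl to 2-fluorophenyl in a cytotoxicity test

A few compounds are considered here, and "the series" means these few. Any claim that something is new, unique, unknown or untested is made for them only; others in the source may bear on it.

In a functional assay on A549 cells (Homo sapiens) for cytotoxicity, read by MTT assay, with a stated time of 48 h (a higher number here means a weaker inhibitor, a lower number a stronger inhibitor), compound 1 `O=c1ccoc2cc(OCc3cn(Cc4ccccc4)nn3)ccc12` gives > 100000 nM as its result, which is a limit and not a number. Compound 2 `O=c1ccoc2cc(OCc3cn(Cc4ccc(F)cc4)nn3)ccc12` gives > 100000 nM as its result, again a limit. Within the data shown here, compound 3 `O=c1ccoc2cc(OCc3cn(Cc4cccc([N+](=O)[O-])c4)nn3)ccc12` gives 9450 nM as the only true number of the three. Compound 4 `O=c1ccoc2cc(OCc3cn(Cc4ccccc4F)nn3)ccc12` is still unmeasured and carries 2-fluorophenyl in place of 3-nitrophenyl on a saturated chain carbon bound to an aromatic nitrogen. Nitro in place of hydrogen gave an at least 10-fold lower number from compound 1 to compound 3 (1.02 log units; beyond the scatter) while fluoro in place of hydrogen gave a step that the two limits leave unreadable from compound 1 to compound 2 as its outcome. Compound 4 has no nitro group, and the reverse of an at least 10-fold lower number from compound 2 to compound 3 (1.02 log units; beyond the scatter) is expected for it, a large step to a higher number. Among the measured compounds shown here, no measured step covers 2-fluorophenyl itself. The estimated change is a 7.4-fold higher number from compound 3 to compound 4 (0.87 log units; beyond the scatter) as a best guess. For compound 4 the estimate is 70000 nM with an expected range from 20000 nM to 200000 nM and a real chance of only a limit.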

Compound 4, half-maximal inhibitory concentration: 10800 nM
Compound 4: middle estimate off by 6.5-fold (0.81 log units), on the high side, and the stated range ends above it.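

In this assay, a nitro group is not required for a measurable result on this saturated chain carbon bound to an aromatic nitrogen: 2-fluorophenyl and 3-nitrophenyl cannot be told apart, with a 1.1-fold higher number from compound 3 to compound 4 (0.06 log units; within the scatter). Fluoro in place of hydrogen on an aromatic carbon, unreadable in the earlier pair, now gives a readable change when the group is 2-fluorophenyl, with an at least 9.2-fold lower number from compound 1 to compound 4 (0.96 log units; beyond the scatter). Where the fluorine sits on the ring also matters, as 2-fluorophenyl in place of 4-fluorophenyl gives an at least 9.2-fold lower number from compound 2 to compound 4 (0.96 log units; beyond the scatter), and both of these last two steps start from a limit, so their true size may be larger: the limit of > 100000 nM in this assay, at which 2 of the 4 values shown sit.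

The compounds shown leave open whether an amine or a carboxylic acid in place of the fluoro of compound 4 would keep this result. They also leave open what a longer chain between the ring and the aromatic nitrogen would do.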